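Sulfinyl-for-phenylsulfanyl exchange on two related cores

The source may hold more compounds than are shown below. What is called first, only, known or untested is meant among the compounds shown, and "the series" means these compounds.

Compound 1 `CNC1=C(Sc2ccccc2)C(=O)c2ncccc2C1=O` and compound 2 `CNC1=C([S+](C)[O-])C(=O)c2ncccc2C1=O` share a core and differ only at a double-bonded ring carbon: a group of 3 heavy atoms (1 carbon, 1 oxygen, 1 sulfur; no ring) in place of a group of 7 heavy atoms (6 carbon, 1 sulfur; one six-membered aromatic ring of carbon only), on a double-bonded ring carbon. In an ADME assay on cells (T-cell, Homo sapiens) for antiproliferative activity, read by MTT assay, with a stated time of 48 h (on this read-out lower numbers stand for stronger inhibition and higher numbers for weaker inhibition), compound 1 gives 12200 nM, and compound 2 gives 11800 nM; the step is a 1.0-fold lower number from compound 1 to compound 2 (0.01 log units; within the scatter). Compound 3 `CNC1=C(Sc2ccccc2)C(=O)c2cccnc2C1=O` has the same atoms as compound 1 joined differently; how the two cores differ is not broken down here. In this assay compound 3 gives 6910 nM, which lies within the scatter of both compound 1 and compound 2.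

Compound 4 `CNC1=C([S+](C)[O-])C(=O)c2cccnc2C1=O` stands to compound 3 as compound 2 stands to compound 1: a group of 3 heavy atoms (1 carbon, 1 oxygen, 1 sulfur; no ring) in place of a group of 7 heavy atoms (6 carbon, 1 sulfur; one six-membered aromatic ring of carbon only), on a double-bonded ring carbon. The place of the exchange is the same in words for both pairs, so this is the same change on the second core. For the measured compounds named here, only one measured instance of it exists, and it left the number essentially unchanged from compound 1 to compound 2. On that basis the expected step from compound 3 to compound 4 is a 1.0-fold higher number from compound 3 to compound 4 (0.01 log units; within the scatter), because the earlier step was a 1.0-fold lower number from compound 1 to compound 2 (0.01 log units; within the scatter). Compound 4 is therefore estimated at 7000 nM, expected between 3500 nM and 14000 nM.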

Compound 4, half-maximal inhibitory concentration: 13400 nM
The estimate for compound 4 lay 1.9-fold (0.28 log units) below the measured number; low and high end bracket the measured number.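

In this assay, the exchange of phenylsulfanyl for the smaller group without a ring, carried onto the second core, gives a 1.9-fold higher number from compound 3 to compound 4 (0.29 log units; within the scatter). Set beside the first instance, the exchange reads the same on both cores within the scatter: the same change on two cores in this assay, a 1.0-fold lower number (0.01 log units; within the scatter) from compound 1 to compound 2 and a 1.9-fold higher number (0.29 log units; within the scatter) from compound 3 to compound 4, 2.0-fold (0.30 log units) apart, within the scatter of two such steps

This shows that, on these two cores, the exchange has no effect that can be told from the scatter, so the near-null result carries over; it does not show a shared direction or a real size of effect, nor that the same would hold on any further core.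

The compounds shown leave open whether any group at this double-bonded ring carbon, such as an amine, a carboxylic acid or a longer chain, would move the number beyond the scatter. They also leave open whether a longer chain in place of the methylamino group would change the reading on either core.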